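A few compounds are considered here, and "the series" means these few. Any claim that something is new, unique, unknown or untested is made for them only; others in the source may bear on it.

Two compounds of the series carry numbers. In a functional assay on NALM-6 cells (Homo sapiens) for cytotoxicity, read by luminescence and CellTiter-Glo, with a stated time of 3 days (on this read-out lower numbers stand for stronger inhibition and higher numbers for weaker inhibition), compound 1 `O=C(Nc1ccc(C(F)(F)F)cc1)c1ccc(Cl)cc1O` gives 1180 nM, the highest of the two; in this assay compound 2 `Cc1cc(C#N)ccc1NC(=O)c1ccc2cccnc2c1O` gives 230 nM, a lower number beyond the scatter. Compound 3 `O=C(Nc1ccc(C(F)(F)F)cc1)c1ccc(Br)cc1O` is not yet measured. It differs from compound 1 by bromo in place of chloro on an aromatic carbon. For the measured compounds named here, no step between measured compounds is available, so no size is known for such a swap; the expected step of a 1.2-fold lower number from compound 1 to compound 3 (0.07 log units; within the scatter) is a small one, not beyond the scatter, in either direction. Compound 3 is estimated at 1000 nM, with a range from 400 nM to 2500 nM.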

Compound 3, half-maximal inhibitory concentration: 690 nM
Compound 3: middle estimate off by 1.4-fold (0.16 log units), on the high side; the range from low to high includes it.
By their numbers in this assay, from the lowest: compound 2; then compounds 3 and 1 (each within the scatter of the next).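

In this assay, the step of a 1.7-fold lower number from compound 1 to compound 3 (0.23 log units; within the scatter) gives the first measured size for bromo in place of chloro on this aromatic carbon, meta to a hydroxy group and para to a large group. At this position, the two halogens are not separated by this read-out. Nothing available accounts for the result.

Still open, from the compounds shown here alone, is whether an amine, a methoxy group or a carboxylic acid at this position would shift the number beyond the scatter. Going by these compounds, the effect of the same swap on other cores also remains unknown.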